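This account rests on a few compounds, and the source may have more. Where it says the series, first, only, none or still open, it means among the compounds named here.

Measured so far in a functional assay on MCF7 cells (Homo sapiens) for antiproliferative activity; a higher number here means a weaker inhibitor of growth, a lower number a stronger inhibitor of growth:
- compound 1, `COc1ccc(-c2nc3cc(F)ccc3s2)cc1O`: 500 nM
- compound 2, `COc1ccc(-c2nc3cc(F)ccc3s2)cc1OC`: a limit, < 0.1 nM
- compound 3, `COc1cc(-c2nc3cc(F)ccc3s2)cc(OC)c1OC`: 1.9 nM

The value of compound 2 in this assay is a limit of the assay and not a number (the limit of < 0.1 nM in this assay, at which 1 of the 3 values shown sits). Compound 1 differs from compound 2 by hydrogen in place of methyl on an oxygen on an aromatic ring, and this step gives an at least 5000-fold higher number from compound 2 to compound 1 (3.69 log units; beyond the scatter). Compound 3 differs from compound 2 by methoxy in place of hydrogen on an aromatic carbon, with an at least 19-fold higher number from compound 2 to compound 3 (1.27 log units; beyond the scatter). Compound 3 and compound 1 show the lower and the higher number of the two plain values.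

Compound 4, `COc1cc(-c2nc3cc(F)ccc3s2)cc(O)c1OC`, has not yet been measured in this assay. It differs from compound 3 by hydrogen in place of methyl on an oxygen on an aromatic ring. This is the same change that was made from compound 2 to compound 1, at a place described in the same words, and there it made a large step. The step from compound 3 to compound 4 is therefore expected to be of a similar kind and size, though how far the number rises is uncertain, since the starting point of compound 2 was only a limit. The estimate for compound 4 is therefore a 1600-fold higher number from compound 3 to compound 4 (3.20 log units; beyond the scatter). Compound 4 is expected to give about 3000 nM in this assay, plausibly between 300 nM and 30000 nM.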

Compound 4, concentration for 50% growth inhibition: 653 nM
For compound 4 the middle estimate is 4.6-fold (0.66 log units) above the measured one; the measured number falls inside the stated range.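

In this assay, the change from methoxy to hydroxy carries over between the two cores in direction, with a 340-fold higher number from compound 3 to compound 4 (2.54 log units; beyond the scatter), but not in size: the same change on two cores in this assay, an at least 5000-fold higher number (3.69 log units; beyond the scatter) from compound 2 to compound 1 and a 340-fold higher number (2.54 log units; beyond the scatter) from compound 3 to compound 4, at least 14-fold (1.16 log units) apart, beyond the scatter of two such steps

Compound 2 gives < 0.1 nM, which is a limit of the assay and not a number, so the step from it has no exact size, and the agreement in direction rests on these two pairs alone.

The reverse reading, adding a group to an aromatic carbon, carries over no better, as hydroxy in place of hydrogen gives an at least 6500-fold higher number from compound 2 to compound 4 (3.81 log units; beyond the scatter), whereas methoxy in place of hydrogen gives a 1.3-fold higher number from compound 1 to compound 4 (0.12 log units; within the scatter), which lies within the scatter: the same change on two cores in this assay, an at least 19-fold higher number (1.27 log units; beyond the scatter) from compound 2 to compound 3 and a 1.3-fold higher number (0.12 log units; within the scatter) from compound 1 to compound 4, at least 14-fold (1.16 log units) apart, beyond the scatter of two such steps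

Still open, going by these compounds, is whether a replacement for methoxy other than hydroxy, such as ethoxy, an amine or a carboxylic acid, would keep the number low on either core. Also open, on these data alone, is whether the change from methoxy to hydroxy would give a step of either size on a core carrying chlorine in place of the fluorine.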